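A Limit Without a Number

The source may report more compounds than this note shows. Statements on the series, on what has been measured and on what is new or still open speak of the compounds shown alone.

Compound 1 `CCCCc1cc2c(=O)cc[nH]c2cc1OCCOc1ccccc1` carries hydrogen at the varied carbon of the shared core. In an ADME assay on J774 cells (Mus musculus) for cytotoxicity (on this read-out lower numbers stand for an effect already at smaller amounts and higher numbers for an effect only at larger amounts of compound), compound 1 gives > 20000 nM, which is a limit of the assay. Compound 2 `CCCCc1cc2c(=O)c(C(=O)NC)c[nH]c2cc1OCCOc1ccccc1`, with methylcarbamoyl at that carbon, gives > 20000 nM, again a limit. Compound 3 `CCCCc1cc2c(=O)c(C(=O)NCC)c[nH]c2cc1OCCOc1ccccc1`, with ethylcarbamoyl there, gives > 20000 nM, also a limit and not a number. Compound 3 therefore has no exact standing in this assay, and the whole series is summed up by the limit of > 20000 nM in this assay, at which 3 of the 3 values shown sit.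

Compound 4 `CCCCc1cc2c(=O)c(I)c[nH]c2cc1OCCOc1ccccc1` has iodo in place of ethylcarbamoyl on an aromatic carbon. The closest measured change is a step that the two limits leave unreadable from compound 1 to compound 3, where the same carbon goes from hydrogen to ethylcarbamoyl. Next to it stand a step that the two limits leave unreadable from compound 1 to compound 2 and a step that the two limits leave unreadable from compound 2 to compound 3. None of these gives a size, and none involves iodo, so they offer only weak guidance. Changes at this carbon have not yet brought any compound to a measurable value, so no step beyond the scatter is expected, although a fall to lower numbers cannot be ruled out. The expected change is a number no higher from compound 3 to compound 4 (the limit leaves the size open). For compound 4 the estimated value is 20000 nM, with an expected range from 7000 nM to 40000 nM.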

Compound 4, half-maximal effective concentration: > 10000 nM
Compound 4 ended at the assay's limit; the forecaster's own chance of this, stated with the estimate: 70%; the middle value is on the limit's open side.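

In this assay compound 4 gives > 10000 nM, a limit and not a number. The steps to compound 4 from compound 1, compound 2 and compound 3 cannot be read, as all four values are limits. The compounds shown leave open how far each lies past its limit, and whether any group at this carbon gives a measurable value in this assay.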